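This account rests on a few compounds, and the source may have more. Where it says the series, first, only, none or still open, it means among the compounds named here.

Compound 1 `O=[N+]([O-])c1ccc(-c2nnc(C3=C(Cl)c4ccccc4CCC3)o2)cc1`: 3280 nM
Compound 2 `Cc1cc2c(cc1C)C(Cl)=C(c1nnc(-c3ccccc3)o1)CCC2`: 2760 nM

In a functional assay on MDA-MB-231 cells (Homo sapiens) for antiproliferative activity, read by sulforhodamine B assay, with a stated time of 48 h (on this read-out lower numbers stand for stronger inhibition of growth and higher numbers for weaker inhibition of growth), compound 2 gives 2760 nM, which lies within the scatter of compound 1 at 3280 nM, so the two cannot be told apart. Compound 3 `Cc1ccc(-c2nnc(C3=C(Cl)c4cc(C)c(C)cc4CCC3)o2)cc1` differs from compound 2 by one change, methyl in place of hydrogen on an aromatic carbon, which turns phenyl into 4-methylphenyl. Going by the values given here, no measured pair shows this change, so no step beyond the scatter is expected in this assay, in either direction. The expected step is a 1.1-fold lower number from compound 2 to compound 3 (0.04 log units; within the scatter), an estimate that stays within the scatter. Compound 3 is estimated at 2500 nM, with an expected range of 1000 nM to 6000 nM.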

Compound 3, concentration for 50% growth inhibition: 1760 nM
Beside the measured number, compound 3's estimate is 1.4-fold (0.15 log units) above it, and the stated range covers the measured number.
By their numbers in this assay, from the lowest: compounds 3, 2 and 1 (each within the scatter of the next).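

In this assay, methyl in place of hydrogen, which turns phenyl into 4-methylphenyl, gives a 1.6-fold lower number from compound 2 to compound 3 (0.20 log units; within the scatter) and so makes no clear difference to the number. Going by these compounds alone, this is the first measured pair that differs in one place, and it shows that this position takes one added carbon with no step beyond the scatter. Nothing measured here offers a reason for this result. Going by these compounds, whether an amine, a carboxylic acid or a longer chain at this position would also leave the number within the scatter remains open.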